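Capping the ring nitrogen of compound 2 with methylsulfonyl

The compounds below may be only part of what the source reports. "The series", "measured", "known", "first", "only" and "open" are said of these compounds alone.

Of the compounds shown here, three sharing one core have been measured so far in an assay on HEK293 cells for agonist activity at Toll-like receptor 8 (Homo sapiens), read by a luciferase reporter, with a stated time of 6 h; a higher number here means that more compound is needed for the effect, a lower number that less compound is needed. Compound 1 `CCCCNc1nc(N)nc2c1CN(Cc1ccccc1)CC2` gives 0.06 uM, compound 3 `CCCCNc1nc(N)nc2c1CN(C)CC2` gives 0.03 uM, and compound 2 `CCCCNc1nc(N)nc2c1CCNC2` gives 0.6 uM. Compound 2 thus stands at the highest number of the three; it needs more compound than compound 1 and than compound 3, and both gaps are beyond the scatter. The step of a 2.0-fold lower number from compound 1 to compound 3 (0.30 log units; within the scatter), by contrast, shows that swapping one substituent on the ring nitrogen for another barely moves the number.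

Compound 4 `CCCCNc1nc(N)nc2c1CCN(S(C)(=O)=O)C2` is the next member. Compared with compound 2 it carries methylsulfonyl in place of hydrogen on an amine nitrogen in a ring. Within the data shown here, no measured step puts this exact group onto the ring nitrogen, so the only guide is that compound 1 and compound 3, each with a group on that nitrogen, sit well below compound 2. A move in the same direction, but smaller, is expected: the estimated step of a 3.0-fold lower number from compound 2 to compound 4 (0.48 log units; beyond the scatter). Compound 4 is therefore expected to give about 0.2 uM in this assay, most likely between 0.03 uM and 1.5 uM.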

Compound 4, minimum effective concentration: 0.8 uM
Compound 4: middle estimate off by 4.0-fold (0.60 log units), on the low side, within the range that was stated.
By their numbers in this assay, from the lowest: compounds 3 and 1 (each within the scatter of the next); then compounds 2 and 4 (each within the scatter of the next).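

Replacing the hydrogen on this amine nitrogen in a ring with methylsulfonyl gives a 1.3-fold higher number from compound 2 to compound 4 (0.12 log units; within the scatter) in this assay and is the only step shown that puts a group in place of that hydrogen. The earlier step swapped one group for another, whereas this one shows that adding methylsulfonyl, with its 4 heavy atoms, leaves the number within the scatter, so a group at this nitrogen does not by itself lower the number. Nothing shown here explains this result.

Still open, going by these compounds, is whether a different group on this nitrogen, such as acetyl or a longer alkyl chain, would shift the number beyond the scatter. A carboxylic acid at the end of such a chain poses the same question.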